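The compounds below may be only part of what the source reports. "The series", "measured", "known", "first", "only" and "open" are said of these compounds alone.

The series shares a diaryl ether bearing a thiazole, capped by a urea. Compound 1 `O=C(Nc1ccccc1)Nc1ccc(Oc2ccc(-c3nccs3)cc2)cc1` carries a plain phenyl on the far urea nitrogen; in a functional assay on MDA-MB-231 cells (Homo sapiens) for inhibition, read by MTT assay and WST assay, with a stated time of 72 h, tested at 10 uM (a higher number here means more inhibition of growth at the concentration tested, a lower number less inhibition of growth), compound 1 is reported as "not determined" (no result reported). Compound 2 `O=C(Nc1ccc(Oc2ccc(-c3nccs3)cc2)cc1)Nc1cc(Br)cc(C(F)(F)F)c1` carries a 3-bromo-5-(trifluoromethyl)phenyl there, and in this assay compound 2 gives 72.8%. Among the compounds with values here, that is the only number available, so compound 2 stands alone, with one further entry that has no figure to compare against.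

The step to compound 3 `CC(=O)Oc1sccc1NC(=O)Nc1ccc(Oc2ccc(-c3nccs3)cc2)cc1` is 2-acetoxythiophen-3-yl in place of 3-bromo-5-(trifluoromethyl)phenyl on an amide-type nitrogen. Within the data shown here, no measured pair in this set shows what such a change does, so the expectation rests on the single value of compound 2 and on the size of the swap. The expected step of a number 22.8 percentage points lower from compound 2 to compound 3 (beyond the scatter) is a decrease that goes beyond the usual scatter, but not a loss of all activity. Compound 3 is therefore estimated at 50%, with a range from 20% to 78%.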

Compound 3, percent growth inhibition at one concentration: 11%
Compound 3: the middle estimate sits 39 percentage points above what was measured; measured number outside the range, below it.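

In this assay, the group on the amide-type nitrogen proves to matter a great deal: with the shared core unchanged, exchanging this one group gives a number 61.8 percentage points lower from compound 2 to compound 3 (beyond the scatter). The earlier compounds shown here offered no comparison, and this first pair shows that growth inhibition at the concentration tested can depend strongly on what is attached at this position. The exchange is not a single small edit, however: the six-membered carbon ring gives way to a five-membered ring with one hetero atom, bromine and trifluoromethyl leave, and an acetoxy group enters, and nothing measured here accounts for the drop.

The compounds shown leave open which part of the exchange matters: whether the loss follows the thiophene ring or the acetoxy group, and whether compound 2 depends on its bromine, its trifluoromethyl or both. They also do not tell how a phenyl carrying a single chlorine, or a thiophene carrying an amine in place of the acetoxy group, would behave on this nitrogen.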